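Sulfur to Selenium Exchange on a Doubly Acylated Core

This account rests on a few compounds, and the source may have more. Where it says the series, first, only, none or still open, it means among the compounds named here.

Two compounds carry measured numbers in a functional assay on MCF7 cells (Homo sapiens) for cytotoxicity, read by MTT assay, with a stated time of 72 h; a lower number here means a stronger inhibitor of growth, a higher number a weaker inhibitor of growth. Compound 1 `CS/C(=N\C(=O)c1sccc1Cl)NC(=O)c1sccc1Cl` gives 10300 nM in this assay. Compound 2 `CS/C(=N\C(=O)c1ccno1)NC(=O)c1ccno1` gives 77800 nM in this assay, the higher of the two numbers; its nearest neighbour is compound 1, and the gap separating them lies beyond the usual scatter of such measurements. The two differ in their aromatic acyl groups, and no single change links them, so their values are read only as they stand.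

Compound 3 `C[Se]/C(=N\C(=O)c1ccno1)NC(=O)c1ccno1` has not yet been measured. It differs from compound 2 by a group of 2 heavy atoms (1 carbon, 1 selenium; no ring) in place of a group of 2 heavy atoms (1 carbon, 1 sulfur; no ring), on a carbon with a double bond to nitrogen, the exchange of one chalcogen for the next in the same position. Going by the values given here, no measured pair in this set covers such an exchange, so its effect cannot be taken from the data. The expectation is a modest move toward a lower number, with a real chance of no change beyond the scatter. Compound 3 is expected to give about 45000 nM in this assay, within a range from 12000 nM to 170000 nM. This corresponds to an estimated step of a 1.7-fold lower number from compound 2 to compound 3 (0.24 log units; within the scatter).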

Compound 3, concentration for 50% growth inhibition: 0.09 nM
For compound 3 the middle estimate is 500000-fold (5.70 log units) above the measured one; the whole stated range lies above it.
By their numbers in this assay, from the lowest: compound 3; then compound 1; then compound 2.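

In this assay, replacing methylsulfanyl with its selenium counterpart on a carbon with a double bond to nitrogen gives an 860000-fold lower number from compound 2 to compound 3 (5.94 log units; beyond the scatter), while both acyl groups stay the same. The earlier compounds shown here differed only in their acyl groups and offered no single change to read, whereas this pair shows that one exchange at this position, of a group for another with the same count of heavy atoms, can by itself move the number enormously in this assay. No measurement shown here explains why the step is so large, and the data offer no cause for it.

The compounds shown leave open whether the same exchange would have a similar effect with the acyl groups of compound 1, since this step rests on a single pair carrying the acyl groups of compound 2. They also leave open how this position would respond to a longer chain on the selenium, such as an ethyl group, or to a different group on the same carbon, such as methoxy or an amine.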